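The source may hold more compounds than are shown below. What is called first, only, known or untested is meant among the compounds shown, and "the series" means these compounds.

Within the data shown here, in a functional assay on HeLa cells (Homo sapiens) for antiproliferative activity, read by sulforhodamine B assay, with a stated time of 48 h (on this read-out higher numbers stand for weaker inhibition and lower numbers for stronger inhibition), compound 1 `COc1ccc(C(=O)/C=C\Nc2ccc(-c3nc4cc(OC)c(OC)c(OC)c4s3)cc2C)cc1F` gives 1200 nM and so holds the lower of the two numbers measured so far. Among the measured compounds shown here, the only other measured compound is compound 2 `COc1ccc(C(=O)/C=C\Nc2ccc(-c3nc4cc(OC)c(OC)c(OC)c4s3)cc2)cc1F` with 7300 nM in this assay as well. Hydrogen in place of methyl on an aromatic carbon accounts for the one measured step, a 6.1-fold higher number from compound 1 to compound 2 (0.78 log units; beyond the scatter) in size.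

For the measured compounds named here, compound 3 `COc1cc(C(=O)/C=C\Nc2ccc(-c3nc4cc(OC)c(OC)c(OC)c4s3)cc2C)cc(OC)c1OC` keeps the core of compound 1 but carries 3,4,5-trimethoxyphenyl in place of 3-fluoro-4-methoxyphenyl on a carbonyl carbon as its single change. Going by the values given here, no measured step touches this place. The step to compound 2, at a 6.1-fold higher number from compound 1 to compound 2 (0.78 log units; beyond the scatter) in size, therefore shows only how far one change has moved the number in this small set and gives no direction for the new one. A step of similar or smaller size is expected in this assay in either direction, and one within the scatter would fit equally well. For compound 3 the estimated value is 1000 nM with an expected range from 250 nM to 4500 nM in this read-out. The estimate thus amounts to an expected 1.2-fold lower number from compound 1 to compound 3 (0.08 log units; within the scatter) and stays close to where compound 1 stands.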

Compound 3, half-maximal inhibitory concentration: 11100 nM
Compound 3: middle estimate off by 11-fold (1.05 log units), on the low side; measured number outside the range, above it.
By their numbers in this assay, from the lowest: compound 1; then compounds 2 and 3 (each within the scatter of the next).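

In this assay the group on the carbonyl carbon proves not to be indifferent: 3,4,5-trimethoxyphenyl in place of 3-fluoro-4-methoxyphenyl gives a 9.3-fold higher number from compound 1 to compound 3 (0.97 log units; beyond the scatter) and so supplies the first measured direction at this place. With the rest of compound 1 kept, the exchange of a group of 9 heavy atoms and 1 hydrogen-bond acceptor for one of 12 heavy atoms and 3 hydrogen-bond acceptors moves the number up, and compound 1 now holds the lowest number of the three, with both of its steps beyond the scatter. Nothing measured on these compounds bears on the reason for this rise.

From the compounds shown here alone, this one exchange removes the fluorine and adds oxygen at once, so it remains open whether plain phenyl, 4-methoxyphenyl or 3-chloro-4-methoxyphenyl on the same carbonyl carbon would keep the number near that of compound 1 or raise it as well. Also open, going by these compounds, is whether hydrogen in place of methyl on the aromatic carbon would have a similar effect when 3,4,5-trimethoxyphenyl sits on the carbonyl carbon.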